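Swapping the aryl on a vinyl sulfone enone

This account rests on a few compounds, and the source may have more. Where it says the series, first, only, none or still open, it means among the compounds named here.

Among the measured compounds shown here, compound 1 `Nc1c(Br)cc(Br)cc1/C=C(\C(=O)c1ccc(Br)cc1)S(=O)(=O)c1ccc(Br)cc1` is the one compound here with a definite number: in a functional assay on DU-145 cells (Homo sapiens) for inhibition, read by trypan blue exclusion, with a stated time of 96 h (on this read-out lower numbers stand for stronger inhibition of growth and higher numbers for weaker inhibition of growth), compound 1 gives 25000 nM. Compound 2 `COc1ccc(C(=O)/C(=C\c2ccc(Br)cc2)Sc2ccc(F)cc2)cc1` in this assay reaches only a limit of the assay, > 100000 nM, which is the limit of > 100000 nM in this assay, at which 1 of the 2 values shown sits. Compound 3 `O=C(/C(=C\c1ccc(Cl)cc1Cl)S(=O)(=O)c1ccc(Br)cc1)c1ccc(Br)cc1` differs from compound 1 in one place: 2,4-dichlorophenyl in place of 2-amino-3,5-dibromophenyl on a double-bonded chain carbon bound to a double-bonded chain carbon. For the measured compounds named here, no measured pair shows what this change does in this assay, so the step is expected to stay within the scatter or lean slightly toward weaker inhibition. Compound 3 is therefore estimated at 30000 nM, with a range from 8000 nM to 100000 nM. This expected step is a 1.2-fold higher number from compound 1 to compound 3 (0.08 log units; within the scatter).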

Compound 3, concentration for 50% growth inhibition: 10000 nM
For compound 3 the middle estimate is 3.0-fold (0.48 log units) above the measured one, and the stated range covers the measured number.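

At this double-bonded chain carbon bound to a double-bonded chain carbon, the aryl group turns out to matter measurably: in this assay the change gives a 2.5-fold lower number from compound 1 to compound 3 (0.40 log units; beyond the scatter). The 2-amino-3,5-dibromophenyl group, with its hydrogen-bond donor, is thus not required for growth inhibition, since the 2,4-dichlorophenyl, with 0 hydrogen-bond donors, does modestly better. Nothing given here bears on why this step occurs.

The compounds shown leave open whether the gain comes from losing the amine or from exchanging bromine for chlorine. They also leave open how a pyridyl ring would behave at this position.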